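A few compounds are considered here, and "the series" means these few. Any claim that something is new, unique, unknown or untested is made for them only; others in the source may bear on it.

Measured in a functional assay on CHO cells with adenosine receptor A1 (Homo sapiens) as the target, read by cAMP accumulation and immunoassay, with a stated time of 6 min, tested at 0.1 uM; on this read-out higher numbers stand for a weaker effect at the one concentration tested and lower numbers for a stronger effect:
compound 1 `Nc1scc(CN2CCN(c3cccc(C(F)(F)F)c3)CC2)c1C(=O)c1ccc(Cl)cc1` gives -30%
compound 2 `Nc1scc(CN2CCN(c3cccc(F)c3)CC2)c1C(=O)c1cccc(C(F)(F)F)c1` gives -12%
compound 3 `Nc1scc(CN2CCN(c3cccc4ccccc34)CC2)c1C(=O)c1ccc(Cl)cc1` gives 0%

Among these three numbers compound 1 stands lowest, that is, it shows the strongest effect at the concentration tested; compound 2 lies closer to it and compound 3 furthest away, both gaps beyond the scatter. Compound 2 differs from compound 1 in more than one place, so its value is noted only as a comparison and not as a single step.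

Compound 4 `Nc1scc(CN2CCN(c3cc(F)ccc3F)CC2)c1C(=O)c1ccc(Cl)cc1` is not yet measured. It differs from compound 1 in one place: 2,5-difluorophenyl in place of 3-(trifluoromethyl)phenyl on an amine nitrogen in a ring

Among the compounds with values here, only one measured step bears on this change, since it alters the same position on the ring nitrogen: a number 30 percentage points higher from compound 1 to compound 3 (beyond the scatter). That step, exchanging the group on the ring nitrogen for a larger aryl, weakened the effect by a modest amount. The exchange in compound 4 is smaller in size, so a smaller shift of the same kind, or none beyond the scatter, is expected. Compound 4 is therefore estimated at -17%, within -37% to 3%. The expected step is a number 13 percentage points higher from compound 1 to compound 4 (beyond the scatter).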

Compound 4, a percentage reported as activity, at one concentration (the size of the read-out at that concentration, not a potency): -13%
The estimate for compound 4 lay 4 percentage points below the measured number; low and high end bracket the measured number.
By their numbers in this assay, from the lowest: compound 1; then compounds 4 and 2 (each within the scatter of the next); then compound 3.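

In this assay the group on the ring nitrogen proves sensitive even to an exchange between two substituted phenyl groups, with a number 17 percentage points higher from compound 1 to compound 4 (beyond the scatter) on going to 2,5-difluorophenyl, so the earlier rise is not confined to the fused naphthalen-1-yl. The entering group has fewer heavy atoms than 3-(trifluoromethyl)phenyl, yet the number moves the same way as with the larger naphthalen-1-yl, and a number 13 percentage points lower from compound 3 to compound 4 (beyond the scatter) sets the difluorophenyl compound apart from the naphthalen-1-yl one, so size alone does not order these three compounds. Nothing measured here gives a reason for these shifts.

The compounds shown leave open whether an unsubstituted phenyl or a methoxyphenyl on the same nitrogen would stay with compound 1 or with compound 4. They also leave open whether a single fluorine on that phenyl ring would give the same number as two.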